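Fluorinated alkanols: extending the difluoro end of compound 3

The source may hold more compounds than are shown below. What is called first, only, known or untested is meant among the compounds shown, and "the series" means these compounds.

Compound 1, `OCCCC(F)CF`: 0.11
Compound 2, `OCCC(F)C(F)F`: 0.29
Compound 3, `OCCCC(F)F`: 0.29

In a physicochemical assay for lipophilicity, read by NMR (a lower number here means a more polar compound, a higher number a more lipophilic compound), compound 3 gives 0.29, level with compound 2 at the digits shown. For the measured compounds named here, the two steps that reach compound 3, a number 0.18 log units higher from compound 1 to compound 3 (within the scatter) and no change at the digits printed from compound 2 to compound 3 (within the scatter), both lie within the scatter, so the three measured values do not separate from one another; the series so far spans only a narrow band.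

Compound 4, `OCCCC(F)(F)C(F)F`, has not yet been measured in this assay. It differs from compound 3 by difluoromethyl in place of hydrogen on a saturated chain carbon bound to two fluorine atoms and a saturated chain carbon. Neither measured step matches this change: a number 0.18 log units higher from compound 1 to compound 3 (within the scatter) swaps fluoro for fluoromethyl, and no change at the digits printed from compound 2 to compound 3 (within the scatter) swaps hydrogen for fluoro, whereas here a difluoromethyl enters in place of hydrogen on a saturated chain carbon bound to two fluorine atoms and a saturated chain carbon. The measured steps therefore only show that exchanges among fluorine, hydrogen and fluoromethyl on this chain stay inside the scatter; nothing measured tells how a difluoromethyl added to the end behaves. An upward step beyond the scatter is nonetheless expected for compound 4, given as a number 0.51 log units higher from compound 3 to compound 4 (beyond the scatter). Compound 4 is estimated at 0.8, with a range from 0.4 to 1.2.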

Compound 4, partition coefficient: 0.97
Estimate against measurement, compound 4: 0.17 log units below, within the range that was stated.
By their numbers in this assay, from the lowest: compounds 1, 2 and 3 (each within the scatter of the next); then compound 4.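

In this assay, for the compounds shown here, difluoromethyl in place of hydrogen on a saturated chain carbon bound to two fluorine atoms and a saturated chain carbon gives a number 0.68 log units higher from compound 3 to compound 4 (beyond the scatter), the first step to lie beyond the scatter. Going by these compounds alone, the two earlier steps, which exchange fluoro, fluoromethyl and hydrogen, both stay within the scatter, so this position is the first on the chain where a single change is seen to separate two compounds in this read-out. The finding rests on this one pair, and no supporting measurement is available to account for the size of the step.

Still open, as far as these compounds go, is whether the step belongs to difluoromethyl specifically or would follow other groups at this place, which methyl, trifluoromethyl or a longer unfluorinated chain on the same carbon would help to settle. Also open, from the compounds shown here alone, is whether a step of similar size would appear in compounds carrying an amine or a carboxylic acid in place of the hydroxyl group.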